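The source may hold more compounds than are shown below. What is called first, only, known or untested is meant among the compounds shown, and "the series" means these compounds.

Measured compounds in a functional assay on UACC-62 cells (Homo sapiens) for inhibition, read by sulforhodamine B assay, with a stated time of 48 h; on this read-out higher numbers stand for weaker inhibition of growth and lower numbers for stronger inhibition of growth:
- compound 1 `Cc1cc(O)cc(-c2nn(CC#N)cc2-c2ccnc(-c3ccc(Oc4ccccc4)cc3)c2)c1`: 18100 nM
- compound 2 `COc1cc(C)cc(-c2nn(CC#N)cc2-c2ccnc(-c3ccc(N(C)C)cc3)c2)c1`: 40700 nM

Compound 2 gives the higher of the two numbers in this assay, and the gap to compound 1 lies beyond the usual scatter. The two compounds differ in two places at once, so no single step can be read from them.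

Compound 3 `Cc1cc(O)cc(-c2nn(CC#N)cc2-c2ccnc(-c3ccc(N(C)C)cc3)c2)c1` is not yet measured. It differs from compound 2 in one place: hydrogen in place of methyl on an oxygen on an aromatic ring. The rest of the structure, including the dimethylaminophenyl part, is kept.

Compound 1 carries the same hydroxy group as compound 3 and gives the lower number, but it also carries a phenoxyphenyl part, so its value cannot be assigned to the methoxy-to-hydroxy change alone. For compound 3 the step from compound 2 is expected to be modest, in the direction of a lower number, possibly not beyond the scatter: a 1.6-fold lower number from compound 2 to compound 3 (0.21 log units; within the scatter). Compound 3 is thus estimated at 25000 nM in this assay, within a range from 9000 nM to 60000 nM.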

Compound 3, concentration for total growth inhibition: 14000 nM
Estimate against measurement, compound 3: 1.8-fold (0.25 log units) above, and the stated range covers the measured number.
By their numbers in this assay, from the lowest: compounds 3 and 1 (each within the scatter of the next); then compound 2.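

In this assay the step at this oxygen can now be read by itself, with the rest of the structure held: methoxy to hydroxy on the 3-methoxy-5-methylphenyl part gives a 2.9-fold lower number from compound 2 to compound 3 (0.46 log units; beyond the scatter) and so goes with stronger inhibition of growth, in this one pair. With the hydroxy held, dimethylamino in place of phenoxy on an aromatic carbon gives a 1.3-fold lower number from compound 1 to compound 3 (0.11 log units; within the scatter) and so does not separate compound 1 from compound 3 on this read-out. The compounds shown carry no measurement that accounts for the effect of losing the methyl from this oxygen.

Open, on these data alone, is how an ethoxy group on this oxygen, or an amine in place of the hydroxy, would read, and whether the methoxy-to-hydroxy step seen with the dimethylaminophenyl part carries over to the phenoxyphenyl part. As far as these compounds go, all the numbers also come from one cell line at one stated time, so how this step reads in other cells remains open.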